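The source may report more compounds than this note shows. Statements on the series, on what has been measured and on what is new or still open speak of the compounds shown alone.

Among the compounds with values here, in a functional assay on T98G cells (Homo sapiens) for cytotoxicity, read by MTT assay, with a stated time of 48 h (on this read-out lower numbers stand for stronger inhibition and higher numbers for weaker inhibition), compound 2 (`C/C(=N\NC(=S)Nc1ccccc1)c1ccccn1`) gives 6.81 nM, the lower of the two numbers so far. Compound 1 (`C/C(=N/NC(=S)Nc1cccc(I)c1)c1ccccn1`) gives 61 nM, a gap beyond the usual scatter, and it also carries iodo. Compound 3 (`C/C(=N\NC(=S)Nc1cccc(I)c1)c1ccccn1`) differs from compound 2 by one change: iodo in place of hydrogen on an aromatic carbon. Within the data shown here, no measured pair shows this change alone, so the expectation is loose, a moderate weakening in the direction of higher numbers. The expected step is a 3.7-fold higher number from compound 2 to compound 3 (0.56 log units; beyond the scatter). Compound 3 is estimated at 25 nM, with a range of 6 nM to 90 nM.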

Compound 3, half-maximal inhibitory concentration: 61 nM
Beside the measured number, compound 3's estimate is 2.4-fold (0.39 log units) below it; the measured number falls inside the stated range.
By their numbers in this assay, from the lowest: compound 2; then compounds 1 and 3 (each within the scatter of the next).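

In this assay, within the data shown here, iodo in place of hydrogen on this aromatic carbon gives a 9.0-fold higher number from compound 2 to compound 3 (0.95 log units; beyond the scatter), the first direct reading of this change, and it goes toward weaker inhibition. Between the two iodo compounds, switching the double bond from Z to E as drawn gives no change at the digits printed from compound 1 to compound 3 (within the scatter). The matching numbers rest on one structural difference alone: the fact that compounds 1 and 3 differ only in the configuration as drawn

From the compounds shown here alone, whether chloro or an amine on the same carbon would bring a similar step remains open. So does whether the double-bond configuration matters as little without iodo.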